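This account rests on a few compounds, and the source may have more. Where it says the series, first, only, none or still open, it means among the compounds named here.

Measured compounds:
Compound 1, `COc1ccccc1-c1nnc(-c2ccc(C(=O)N/N=C/c3ccccc3F)cc2)o1`, 313000 nM in an ADME assay on THP-1 cells (Homo sapiens) for cytotoxicity; a higher number here means a weaker inhibitor, a lower number a stronger inhibitor
Compound 2, `COc1ccc(/C=N/NC(=O)c2ccc(-c3nnc(-c4ccccc4OC)o3)cc2)c(O)c1`, 308000 nM

Compound 2 stands with the lowest of the two numbers in this assay, but its nearest neighbour compound 1 sits so close that the two cannot be told apart. Among the measured compounds shown here, the only step that bears on the aryl group attached to the carbon with a double bond to nitrogen is a 1.0-fold lower number from compound 1 to compound 2 (0.01 log units; within the scatter), and it shows that exchanging that aryl group left the number where it was. Compound 3, `COc1ccccc1-c1nnc(-c2ccc(C(=O)N/N=C/c3ccc(O)cc3)cc2)o1`, has not yet been measured; it differs from compound 2 in one place: 4-hydroxyphenyl in place of 2-hydroxy-4-methoxyphenyl on a carbon with a double bond to nitrogen. For the measured compounds named here, since the one comparable step stayed within the scatter, compound 3 is expected to show no step beyond the scatter either, which means an expected step of a 1.0-fold higher number from compound 2 to compound 3 (0.00 log units; within the scatter). The estimate for compound 3 in this assay is therefore 310000 nM, within a range from 150000 nM to 620000 nM.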

Compound 3, half-maximal inhibitory concentration: 261000 nM
The estimate for compound 3 lay 1.2-fold (0.07 log units) above the measured number; low and high end bracket the measured number.
By their numbers in this assay, from the lowest: compounds 3, 2 and 1 (each within the scatter of the next).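

In this assay, a third aryl group on the carbon with a double bond to nitrogen again produces no step beyond the scatter: a 1.2-fold lower number from compound 2 to compound 3 (0.07 log units; within the scatter), and a 1.2-fold lower number from compound 1 to compound 3 (0.08 log units; within the scatter). Going from the 9 heavy atoms of 2-hydroxy-4-methoxyphenyl to the 7 of 4-hydroxyphenyl therefore leaves the reading unresolved from the earlier values, and 2-fluorophenyl, 2-hydroxy-4-methoxyphenyl and 4-hydroxyphenyl cannot be told apart here. Nothing available offers an explanation for this flat result.

Going by these compounds, all three groups at this place are six-membered aromatic rings of carbon only, so it remains open whether a group without such a ring, such as an amine, a carboxylic acid or a longer alkyl chain, would shift the number. The shared core is also the same throughout, so the compounds shown say nothing about changes made there.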